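The source may hold more compounds than are shown below. What is called first, only, known or untested is meant among the compounds shown, and "the series" means these compounds.

Compound 1 `CC[C@@H](C)[C@H](NC(=O)c1ccc(C(CC)(CC)c2ccc(OCC(=O)C(C)(C)C)c(C)c2)n1CC)C(=O)OC` gives 590 nM in an assay on HL-60 cells for agonist activity at vitamin D3 receptor (Homo sapiens), read by microscopy, with a stated time of 96 h (a higher number here means that more compound is needed for the effect, a lower number that less compound is needed), the highest of the three numbers in that set. Compound 2 `CCn1c(C(=O)N(CCC#N)CCC#N)ccc1C(CC)(CC)c1ccc(OCC(O)C(C)(C)C)c(C)c1` gives 97 nM and compound 3 `C#CC(C)OC(=O)c1ccc(C(CC)(CC)c2ccc(OCC(O)C(C)(C)C)c(C)c2)n1CC` gives 200 nM. Compound 4 `CCn1c(C(=O)OC(C)CCO)ccc1C(CC)(CC)c1ccc(OCC(=O)C(C)(C)C)c(C)c1` has not been measured; it differs from compound 1 in one place: a group of 6 heavy atoms (4 carbon, 2 oxygen; no ring) in place of a group of 10 heavy atoms (7 carbon, 1 nitrogen, 2 oxygen; no ring), on a carbonyl carbon. Among the measured compounds shown here, the only measured step that bears on this is the replacement of an amide nitrogen substituent by an ester oxygen substituent on the same carbonyl carbon, a 2.1-fold higher number from compound 2 to compound 3 (0.31 log units; beyond the scatter), which moved the number upward by a modest amount. Since compound 1 already stands at the top, and compound 3, the one measured ester, sits lower, the expected step of a 1.5-fold lower number from compound 1 to compound 4 (0.17 log units; within the scatter) is downward, modest and uncertain. Compound 4 is therefore estimated at 400 nM, within a range from 130 nM to 1200 nM.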

Compound 4, half-maximal effective concentration: 380 nM
Beside the measured number, compound 4's estimate is 1.1-fold (0.02 log units) above it; measured number inside the range.
By their numbers in this assay, from the lowest: compound 2; then compounds 3, 4 and 1 (each within the scatter of the next, the first and the last beyond it).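

At this carbonyl carbon, replacing the (1-(methoxycarbonyl)-2-methylbutyl)amino group with an ester group that has no defined stereocentres gives a 1.6-fold lower number from compound 1 to compound 4 (0.19 log units; within the scatter) in this assay. The two defined stereocentres and the amide nitrogen of compound 1 are therefore not needed to keep the number within the scatter, whereas the earlier change at this carbon, a 2.1-fold higher number from compound 2 to compound 3 (0.31 log units; beyond the scatter), went beyond it. No measurement offered here explains this result.

The compounds shown leave open how a free carboxylic acid or a simple primary amide on this carbonyl carbon would read.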